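The source may report more compounds than this note shows. Statements on the series, on what has been measured and on what is new or still open speak of the compounds shown alone.

Measured so far:
compound 1 `CC(C)c1c(C(=O)NCc2ccccc2)nn(-c2ccc(F)cc2)c1OC[C@@H](O)C[C@@H](O)CC(=O)O`, 3.8 nM
compound 2 `CC(C)c1c(C(=O)N2CCCCC2)nn(-c2ccc(F)cc2)c1OC[C@@H](O)C[C@@H](O)CC(=O)O`, 47 nM

In an assay on microsomes from liver for inhibition of 3-hydroxy-3-methylglutaryl-coenzyme A reductase (Rattus norvegicus) (a lower number here means a stronger inhibitor, a higher number a weaker inhibitor), compound 2 has the highest, that is the weakest, of the two numbers shown; compound 1 stands nearest with 3.8 nM.

The next compound, compound 3 `COc1cccc(CNC(=O)c2nn(-c3ccc(F)cc3)c(OC[C@@H](O)C[C@@H](O)CC(=O)O)c2C(C)C)c1`, is not yet measured. It differs from compound 2 in one place: (3-methoxybenzyl)amino in place of piperidin-1-yl on a carbonyl carbon.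

Going by the values given here, one measured step bears on this change. Going from the benzylamino group to the piperidin-1-yl group gave a 12-fold higher number from compound 1 to compound 2 (1.09 log units; beyond the scatter). Compound 3 carries a (3-methoxybenzyl)amino group, which is the benzylamino group of compound 1 with one added methoxy group, so the step from compound 2 to compound 3 largely reverses that measured step. A sizeable move toward lower numbers is therefore expected, about a 9.4-fold lower number from compound 2 to compound 3 (0.97 log units; beyond the scatter). Because compound 1 gives 3.8 nM, compound 3 is expected to land close to it, and an estimate of 5 nM is made, with a range from 1.5 nM to 15 nM.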

Compound 3, half-maximal inhibitory concentration: 16 nM
Compound 3: middle estimate off by 3.2-fold (0.51 log units), on the low side; the measured number lies above the stated range.
By their numbers in this assay, from the lowest: compound 1; then compound 3; then compound 2.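

In this assay, the (3-methoxybenzyl)amino group still gives a stronger inhibitor than the piperidin-1-yl group, with a 2.9-fold lower number from compound 2 to compound 3 (0.47 log units; beyond the scatter), but this recovers only part of the gap seen earlier in a 12-fold higher number from compound 1 to compound 2 (1.09 log units; beyond the scatter). The comparison with the unsubstituted benzylamino group shows that the aromatic ring of this side group is sensitive to added substitution: methoxy in place of hydrogen on an aromatic carbon gives a 4.2-fold higher number from compound 1 to compound 3 (0.62 log units; beyond the scatter), a change that is modest in size but beyond the scatter. Nothing available explains why this added methoxy group weakens inhibition or why the benzylamino-type groups outperform the piperidin-1-yl group.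

The compounds shown leave open whether another small group on the same aromatic ring, such as fluorine or a methyl group, would shift the number as far as methoxy does. They also leave open how much of the advantage of the benzylamino group rests on the amide hydrogen, a question that a benzyl(methyl)amino group on the same carbonyl carbon could address by keeping the aromatic ring while removing that hydrogen.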